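The compounds below may be only part of what the source reports. "The series", "measured", "known", "first", "only" and "open" are said of these compounds alone.

Working notes on the series. Compound 1 `Cc1c(O)c(C)c2c(c1O)C(=O)CC(c1ccccc1O)O2`, compound 2 `Cc1c(O)c(C)c2c(c1O)C(=O)CC(c1ccc(Cl)cc1)O2` and compound 3 `Cc1c(O)c(C)c2c(c1O)C(=O)CC(c1ccco1)O2` share one core and have all been tested in a functional assay on VSMC cells (Rattus norvegicus); a higher number here means a weaker inhibitor, a lower number a stronger inhibitor. There, compound 1 gives "not active" (no number reported) and compound 2 gives "not active" (no number reported), so neither offers a number for comparison. For the measured compounds named here, compound 3 gives 6700 nM, the only number so far, and it therefore cannot yet be ranked numerically against another compound.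

Compound 4 `Cc1c(O)c(C)c2c(c1O)C(=O)CC(c1ccsc1)O2` has not yet been measured in this assay. It carries thiophen-3-yl in place of furan-2-yl on a saturated ring carbon, next to the ring oxygen: thiophen-3-yl in place of furan-2-yl on a saturated ring carbon. Both groups are five-membered aromatic rings with 1 hetero atom, and the counted difference is confined to the hetero atom.

Going by the values given here, no step between measured compounds is available to size this change, so the expectation rests on the single value and the structural comparison. No shift beyond the usual scatter is expected, and no direction is favoured. The estimated step is a 1.0-fold higher number from compound 3 to compound 4 (0.02 log units; within the scatter). A result without a number remains possible, as seen with compound 1 at "not active" (no number reported) and compound 2 at "not active" (no number reported). For compound 4 the expected value is 7000 nM, with an estimated range of 2500 nM to 20000 nM.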

Compound 4, half-maximal inhibitory concentration: "not active" (no number reported)
Compound 4: no number reported; there is nothing to compare the estimate with.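

In this assay compound 4 gives "not active" (no number reported), so no new step can be read from compound 3 to compound 4. No evidence on hand bears on this result. The compounds shown leave open how far any single change on the shared core shifts the value in this assay, with compound 3 alone carrying a number, 6700 nM.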